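Cyanoguanidine aryl swap: trifluoromethyl to chloro-fluoro pattern

The compounds below may be only part of what the source reports. "The series", "measured", "known", "first", "only" and "open" are said of these compounds alone.

Compound 1 `C/N=C(\NC#N)N[C@@H]1c2cc(C#N)ccc2OC(C)(C)[C@H]1O` gives 200 nM
Compound 2 `CC1(C)Oc2ccc(C#N)cc2[C@@H](NC(=O)Nc2ccncc2)[C@@H]1O` gives 8500 nM
Compound 3 `CC1(C)Oc2ccc(C#N)cc2[C@@H](/N=C(\NC#N)Nc2cccc(C(F)(F)F)c2)[C@@H]1O` gives 1600 nM

These three compounds share a common core and were tested in a functional assay (aorta) with Rattus norvegicus as the target; on this read-out lower numbers stand for stronger inhibition and higher numbers for weaker inhibition. Within this set compound 3 holds the second highest number. Its nearest neighbour is compound 2, whose value in this assay stands well above it and beyond the scatter of the measurement. Its furthest is compound 1, whose value lies well below it, again beyond the scatter. Among the compounds with values here, no pair among the three differs in a single place, so the individual contributions of the cyanoguanidine and of its substituent cannot be separated from these values alone.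

Compound 4 `CC1(C)Oc2ccc(C#N)cc2[C@@H](/N=C(\NC#N)Nc2ccc(Cl)c(F)c2)[C@@H]1O` has not yet been measured in this assay. It differs from compound 3 in one place: 4-chloro-3-fluorophenyl in place of 3-(trifluoromethyl)phenyl on an amine nitrogen. With no measured step of this kind in hand, one aryl group is replaced by another of similar size, and the expectation is a step from compound 3 to compound 4 of a 1.1-fold lower number from compound 3 to compound 4 (0.03 log units; within the scatter), that is, none beyond the scatter in either direction. On that basis compound 4 is expected to give about 1500 nM in this assay, with a likely range from 500 nM to 4500 nM.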

Compound 4, half-maximal inhibitory concentration: 1660 nM
Beside the measured number, compound 4's estimate is 1.1-fold (0.04 log units) below it, and the stated range covers the measured number.
By their numbers in this assay, from the lowest: compound 1; then compounds 3 and 4 (each within the scatter of the next); then compound 2.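

Within the data shown here, this is the first step in the set that changes a single place, and it comes to a 1.0-fold higher number from compound 3 to compound 4 (0.02 log units; within the scatter) in this assay. At this amine nitrogen, then, 4-chloro-3-fluorophenyl and 3-(trifluoromethyl)phenyl cannot be told apart on this read-out, even though the entering group has fewer heavy atoms and a different set of halogens on the ring. No measurement in hand gives a reason for this result.

From the compounds shown here alone, the step speaks only for these two halogen-bearing phenyl groups, so it remains open whether plain phenyl, or a phenyl ring carrying a carboxylic acid or an amine, would give a number within the scatter of these two or one clearly apart from them. The part played by the cyanoguanidine itself also remains open, as no pair among the compounds shown differs there alone, and a urea bearing the same 4-chloro-3-fluorophenyl group would be needed to read that contribution directly.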